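Removing one chain methyl from compound 1

The compounds below may be only part of what the source reports. "The series", "measured", "known", "first", "only" and "open" are said of these compounds alone.

In an ADME assay on Caco-2 cells (Homo sapiens) for cytotoxicity, read by neutral red uptake, with a stated time of 72 h (a higher number here means that more compound is tolerated, a lower number that less compound is tolerated), compound 1 (`COc1cc(NC(C)CCCNC(=O)C2CCC3(CC2)OOC2(OO3)C3CC4CC(C3)CC2C4)c2ncccc2c1-c1ccc(F)cc1`) gives > 50000 nM as a limit and not a number. Compound 2 (`COc1cc(NC(C)CCCNC(=O)C2CCC3(CC2)OOC2(OO3)C3CC4CC(C3)CC2C4)c2ncccc2c1-c1ccc(C(F)(F)F)cc1`) gives > 50000 nM as a limit too. For compound 3 (`COc1cc(NC(C)CCCNC(=O)C2CCC3(CC2)OOC2(OO3)C3CC4CC(C3)CC2C4)c2ncccc2c1Br`) the entry reads "not determined" (no result reported) and offers no comparison. Compound 1 thus stands at the limit of > 50000 nM in this assay, at which 2 of the 3 values shown sit, in the series.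

Going by the values given here, compound 4 (`COc1cc(NCCCCNC(=O)C2CCC3(CC2)OOC2(OO3)C3CC4CC(C3)CC2C4)c2ncccc2c1-c1ccc(F)cc1`) differs from compound 1 by hydrogen in place of methyl on a saturated chain carbon bound to a nitrogen on an aromatic ring and a saturated chain carbon as its single change, with hydrogen in place of methyl on a saturated chain carbon bound to a nitrogen on an aromatic ring and a saturated chain carbon. Among the compounds with values here, the only measured step is a step that the two limits leave unreadable from compound 1 to compound 2 with trifluoromethyl in place of fluoro on an aromatic carbon. It has no readable size and does not concern this methyl. No step beyond the scatter is therefore expected in this assay, in either direction. The expected step is a number no higher from compound 1 to compound 4 (the limit leaves the size open) on this estimate. For compound 4 the estimate is 50000 nM with an expected range from 20000 nM to 100000 nM in this assay.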

Compound 4, half-maximal cytotoxic concentration: 10200 nM
Compound 4: the middle estimate sits 4.9-fold (0.69 log units) above what was measured; the measured number lies below the stated range.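

In this assay, this chain carbon proves sensitive to a small change: hydrogen in place of methyl gives an at least 4.9-fold lower number from compound 1 to compound 4 (0.69 log units; beyond the scatter), and since the starting point is a limit, the true step may be larger. Going by these compounds alone, this is the first readable step, as the step between the two limits cannot be read, so the earlier compounds could not show that a change here moves the number. Compound 4 is the only compound shown with a measured number, and the others with a result stay at a limit: the limit of > 50000 nM in this assay, at which 2 of the 4 values shown sit.

The compounds shown leave open whether an ethyl group on this carbon would keep the number at the limit. They also leave open whether removing the methyl gives a similar step when trifluoromethyl stands in place of fluoro.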